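From 4-Hydroxyphenyl to 2,6-Dimethoxyphenyl at One Site

This account rests on a few compounds, and the source may have more. Where it says the series, first, only, none or still open, it means among the compounds named here.

In a functional assay on T47D cells (Homo sapiens) for inhibition, read by sulforhodamine B assay, with a stated time of 48 h (a higher number here means a weaker inhibitor of growth, a lower number a stronger inhibitor of growth), compound 1 (`O=C(Cc1csc2nc(-c3ccc(Br)cc3)cn12)N/N=C/c1ccccc1O`) gives 23400 nM as its reading. Compound 2 (`O=C(Cc1csc2nc(-c3ccc(Br)cc3)cn12)N/N=C/c1ccc(O)cc1`) gives > 100000 nM as its reading, and this is a limit of the assay, not a number. Compound 2 therefore has no exact place on the scale (the limit of > 100000 nM in this assay, at which 1 of the 2 values shown sits).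

Compound 3 (`COc1cccc(OC)c1/C=N/NC(=O)Cc1csc2nc(-c3ccc(Br)cc3)cn12`) carries 2,6-dimethoxyphenyl in place of 4-hydroxyphenyl on a carbon with a double bond to nitrogen while the shared core stays the same. Going by the values given here, the one measured step at this place is an at least 4.2-fold higher number from compound 1 to compound 2 (0.63 log units; beyond the scatter) on going from 2-hydroxyphenyl to 4-hydroxyphenyl. The entering group has a 2 in its name, as the group of compound 1 does, but it holds no hydroxy group, so that step is only a loose guide. Compound 3 is expected to move part of the way back toward compound 1 at 23400 nM in this assay without reaching it. The expected change is a modest one to a lower number, estimated as an at least 2.2-fold lower number from compound 2 to compound 3 (0.34 log units; beyond the scatter) with some chance of only a limit being reported. The estimate for compound 3 is 45000 nM with 15000 nM to 100000 nM as its expected range.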

Compound 3, concentration for total growth inhibition: > 100000 nM
Compound 3: a limit, no number; the forecaster's own chance of this, stated with the estimate: 35%; at least 2.2-fold (0.34 log units) between middle value and limit.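

In this assay compound 3 gives > 100000 nM, which is a limit of the assay and not a number. Going by these compounds alone, the one readable step is an at least 4.2-fold higher number from compound 1 to compound 3 (0.63 log units; beyond the scatter), so a group with a 2 in its name does not by itself keep a reading on the scale, as 2,6-dimethoxyphenyl, which holds no hydroxy group, does not restore the reading given by 2-hydroxyphenyl. Of the three groups shown on the carbon with a double bond to nitrogen, only 2-hydroxyphenyl gives a number, and the step between compound 2 and compound 3 cannot be read, since both values are limits: the limit of > 100000 nM in this assay, at which 2 of the 3 values shown sit.

The change from 2-hydroxyphenyl to 2,6-dimethoxyphenyl alters more than one feature of the group at once, so the compounds shown do not separate the loss of the hydroxy group from the gain of the methoxy groups. On these data alone, whether a single methoxy group or an amine in place of the hydroxy group of compound 1 would keep a measurable reading remains open, as does how far compound 2 and compound 3 lie beyond the limit.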